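The source may hold more compounds than are shown below. What is called first, only, known or untested is meant among the compounds shown, and "the series" means these compounds.

Two compounds on a shared core open this account, compound 1 (`C=CCOc1cc(OC)c(C(=O)/C=C/C=C/c2ccccc2)c(OCC=C)c1`) and compound 2 (`C=CCOc1cc(OC)c(C(=O)/C=C/c2ccc(O)cc2)c(OCC=C)c1`), while a third, compound 3 (`C=CCOc1cc(OC)c(C(=O)/C=C/c2cccc(OC)c2)c(OCC=C)c1`), still awaits its result. The read-out is an ADME assay on Vero cells (Chlorocebus sabaeus) for cytotoxicity, read by MTT assay; on this read-out higher numbers stand for weaker inhibition and lower numbers for stronger inhibition. In this assay compound 1 stands without a number, its entry reading "not determined" (no result reported), so it gives no footing on the scale. Compound 2 supplies the only figure so far, at 76400 nM.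

The step of interest starts from compound 1 and leads to compound 3: 3-methoxyphenyl in place of 2-phenylethenyl on a double-bonded chain carbon bound to a double-bonded chain carbon. Here 3-methoxyphenyl takes the place of 2-phenylethenyl on a double-bonded chain carbon bound to a double-bonded chain carbon.

With no value for compound 1, the size of this step in this assay cannot be read from the data, and no direction can be expected from it. Within the data shown here, the sole anchor is compound 2 at 76400 nM, so compound 3 is expected to fall near that figure, with no shift beyond the usual scatter. For compound 3 the estimated value is 75000 nM, with an expected range from 30000 nM to 190000 nM.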

Compound 3, half-maximal inhibitory concentration: 142000 nM
The estimate for compound 3 lay 1.9-fold (0.28 log units) below the measured number, within the range that was stated.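

In this assay, among these compounds, putting 3-methoxyphenyl in place of 4-hydroxyphenyl on a double-bonded chain carbon bound to a double-bonded chain carbon gives a 1.9-fold higher number from compound 2 to compound 3 (0.27 log units; within the scatter) as the first comparison that can be read at this place, and it shows that this exchange of one substituted phenyl group for the other leaves the read-out within the scatter. The step that leads from compound 1 to compound 3, and with it the exchange of 2-phenylethenyl for 3-methoxyphenyl, cannot be read, since compound 1 has no number to set against the new result. No measurement shown here offers an explanation for the close agreement of the two values.

The compounds shown leave open whether this place stays as undemanding with a phenyl ring carrying an amine or a carboxylic acid, or with a longer chain in place of the ring. They also leave open whether a value for compound 1 would set 2-phenylethenyl apart from the two substituted phenyl groups or place it with them on this scale.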